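A few compounds are considered here, and "the series" means these few. Any claim that something is new, unique, unknown or untested is made for them only; others in the source may bear on it.

Among the compounds with values here, compound 1 `COc1c(C)c(C/C=C(\C)CCC=C(C)C)c(OC)c(OC)c1OC` is the better of the two compounds measured so far. In an assay on cells for inhibition of Amine oxidase [flavin-containing] B (Homo sapiens), read by fluorescence, with stated times of 10 min and 20 min, tested at 25 uM (on this read-out higher numbers stand for more inhibition at the one concentration tested (going by the name of the read-out) and lower numbers for less inhibition), compound 1 gives 38%, the highest of the two numbers. Compound 2 `CC(C)=CCc1c(C)cc(O)cc1O` gives 4.2% in this assay, a gap below compound 1 that lies beyond the usual scatter. Compound 3 `COc1c(C)c(CC=C(C)C)c(OC)c(OC)c1OC` has not been measured; it differs from compound 1 by hydrogen in place of 3-methylbut-2-en-1-yl on a saturated chain carbon bound to a double-bonded chain carbon, with the shared core otherwise untouched. Within the data shown here, no measured pair shows this same change, so any expectation rests on the two numbers alone. Compound 2 carries a 3-methylbut-2-en-1-yl group on a different core and gives the lower number, which is only a loose pointer. A downward step, moderate and near the edge of the scatter, is expected in this assay, namely a number 16 percentage points lower from compound 1 to compound 3 (beyond the scatter). Compound 3 is accordingly estimated at 22%, within a range from 6% to 38%.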

Compound 3, a percentage reported as inhibition, at one concentration (the size of the read-out at that concentration, not a potency): 7.2%
For compound 3 the middle estimate is 14.8 percentage points above the measured one; low and high end bracket the measured number.
By their numbers in this assay, from the lowest: compounds 2 and 3 (each within the scatter of the next); then compound 1.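

In this assay, within the data shown here, the loss of the 3-methylbut-2-en-1-yl group on a saturated chain carbon bound to a double-bonded chain carbon gives a number 30.8 percentage points lower from compound 1 to compound 3 (beyond the scatter) on the shared core, the first direct reading of this change. The step is large, so at this position the group with its 5 carbon atoms and its double bond matters for the inhibition read at the one concentration tested. Nothing in the available data explains why the step is this large.

The compounds shown cannot separate the effect of chain length from that of the double bond in the group that leaves. Going by these compounds, how a saturated chain of the same length, a longer chain or a chain ending in an amine would read at this position remains open.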